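Working notes: one added methoxy on the acetyl compound

This account rests on a few compounds, and the source may have more. Where it says the series, first, only, none or still open, it means among the compounds named here.

In a functional assay on ECa-109 cells (Homo sapiens) for cytotoxicity, read by MTT assay, with a stated time of 48 h (a higher number here means a weaker inhibitor, a lower number a stronger inhibitor), compound 1 `COc1ccc(-c2c(-c3cc(OC)c(OC)c(OC)c3)noc2N)cc1` gives 5840 nM, compound 2 `COc1ccc(-c2c(-c3cc(OC)c(OC)c(OC)c3)noc2N)cc1OC` gives 20600 nM and compound 3 `COc1ccc(-c2c(-c3cc(OC)c(OC)c(OC)c3)noc2NC(C)=O)cc1` gives 10800 nM. Compound 3 lies within the scatter of both the others. Compound 4 `COc1ccc(-c2c(-c3cc(OC)c(OC)c(OC)c3)noc2NC(C)=O)cc1OC` differs from compound 3 by methoxy in place of hydrogen on an aromatic carbon, which turns 4-methoxyphenyl to 3,4-dimethoxyphenyl. The same replacement, made without the acetyl, gave a 3.5-fold higher number from compound 1 to compound 2 (0.55 log units; beyond the scatter), a modest step beyond the scatter. The acetyl replacement alone gave a 1.8-fold higher number from compound 1 to compound 3 (0.27 log units; within the scatter), which is within the scatter. This single precedent points to a modest move towards a weaker inhibitor, and the expected step is a 2.8-fold higher number from compound 3 to compound 4 (0.44 log units; beyond the scatter). For compound 4 the estimated value is 30000 nM, with an expected range of 12000 nM to 75000 nM.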

Compound 4, half-maximal inhibitory concentration: 17700 nM
For compound 4 the middle estimate is 1.7-fold (0.23 log units) above the measured one; the range from low to high includes it.
By their numbers in this assay, from the lowest: compounds 1, 3, 4 and 2 (each within the scatter of the next, the first and the last beyond it).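

Methoxy in place of hydrogen, turning 4-methoxyphenyl to 3,4-dimethoxyphenyl, now also reads on the acetyl core, where the step is a 1.6-fold higher number from compound 3 to compound 4 (0.21 log units; within the scatter). The size of this change does not separate the two cores: the same change on two cores in this assay, a 3.5-fold higher number (0.55 log units; beyond the scatter) from compound 1 to compound 2 and a 1.6-fold higher number (0.21 log units; within the scatter) from compound 3 to compound 4, 2.2-fold (0.33 log units) apart, within the scatter of two such steps. Acetyl in place of hydrogen on the nitrogen, read on the 3,4-dimethoxyphenyl pair, is a 1.2-fold lower number from compound 2 to compound 4 (0.07 log units; within the scatter), and its two readings also stay together: the same change on two cores in this assay, a 1.8-fold higher number (0.27 log units; within the scatter) from compound 1 to compound 3 and a 1.2-fold lower number (0.07 log units; within the scatter) from compound 2 to compound 4, 2.2-fold (0.33 log units) apart, within the scatter of two such steps.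

Two cores cannot settle whether the methoxy step depends on the acetyl. As far as these compounds go, how a hydroxy or a fluorine at this carbon, or a longer acyl chain on the nitrogen, would read remains open.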